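Tolerability notes on the shared-core series

The compounds below may be only part of what the source reports. "The series", "measured", "known", "first", "only" and "open" are said of these compounds alone.

Measured so far in an ADME assay on HepG2 cells (Homo sapiens) for cytotoxicity, read by MTT assay, with a stated time of 72 h; a higher number here means that more compound is tolerated, a lower number that less compound is tolerated:
compound 1 `Cc1ccc(-c2cc3nc(N)[nH]c(=O)c3s2)cc1` — "nd(insoluble)" (no result reported)
compound 2 `CCCNc1nc2cc(-c3ccc(C)cc3)sc2c(=O)[nH]1` — > 62500 nM
compound 3 `CCCCCCNc1nc2cc(-c3ccc(C)cc3)sc2c(=O)[nH]1` — 10600 nM

Compound 1 carries no number in this assay; its entry reads "nd(insoluble)" (no result reported). For compound 2 the value > 62500 nM is a limit of this assay, not a number. For the measured compounds named here, compound 3 gives 10600 nM and is therefore the only compound of the three with a single number in this assay. The entry of compound 2 is a limit and the entry of compound 1 is a missing result. Going by the values given here, the one measured step is an at least 5.8-fold lower number from compound 2 to compound 3 (0.77 log units; beyond the scatter), which rests on the limit of > 62500 nM in this assay, at which 1 of the 3 values shown sits, and so is known only as a lower bound on its size.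

Compound 4 `Cc1ccc(-c2cc3nc(NC(C)c4ccccc4)[nH]c(=O)c3s2)cc1` differs from compound 3 by 1-phenylethyl in place of hexyl on a nitrogen on an aromatic ring. Among the compounds with values here, no measured step covers this swap: the step from compound 2 to compound 3 concerns lengthening of the chain, not exchanging the chain for a ring-bearing group, so it gives no direction for compound 4. The expectation is therefore a step of a 1.1-fold higher number from compound 3 to compound 4 (0.05 log units; within the scatter), within the scatter. Compound 4 is expected to give about 12000 nM, estimated between 4000 nM and 40000 nM.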

Compound 4, half-maximal cytotoxic concentration: 9200 nM
Compound 4: middle estimate off by 1.3-fold (0.12 log units), on the high side, and the stated range covers the measured number.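

In this assay, replacing hexyl with 1-phenylethyl on the nitrogen on an aromatic ring gives a 1.2-fold lower number from compound 3 to compound 4 (0.06 log units; within the scatter), so a group with a six-membered aromatic ring and a straight chain cannot be told apart at this position. The step of an at least 6.7-fold lower number from compound 2 to compound 4 (0.83 log units; beyond the scatter) shows that lower tolerance relative to the propyl compound is not confined to the hexyl chain. Its size is only a bound, because compound 2 stands at a limit of the assay: the limit of > 62500 nM in this assay, at which 1 of the 4 values shown sits.

The series does not show whether benzyl, with its ring closer to the nitrogen, or a chain ending in an amine or a carboxylic acid would stay with compound 3 and compound 4 or move towards compound 2. It also leaves open where between propyl and hexyl the tolerance changes, as butyl and pentyl are not among the compounds shown.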